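The compounds below may be only part of what the source reports. "The series", "measured", "known", "first", "only" and "open" are said of these compounds alone.

Working notes on the series in a physicochemical assay for lipophilicity, read by HPLC, at pH 7.4; a higher number here means a more lipophilic compound, a lower number a more polar compound: compound 1 (`Cc1ccc(-n2nccn2)c(C(=O)N2CCC[C@@H]2Cn2ccc(-c3ccc(F)cn3)n2)c1`) gives 3.06, compound 2 (`Cc1ccc(-n2nccn2)c(C(=O)N2CCC[C@H]2Cn2ccc(-c3ccc(F)cn3)n2)c1`) gives 3.08 and compound 3 (`Cc1ccc(-n2nccn2)c(C(=O)N2CCCC[C@@H]2Cn2ccc(-c3ccc(F)cn3)n2)c1`) gives 2.95. All three numbers lie within the scatter of one another, so compound 3 stands level with the other two on this read-out.

Compound 4 (`Cc1ccc(-n2nccn2)c(C(=O)N2CCCC[C@H]2Cn2ccc(-c3ccc(F)cn3)n2)c1`) is still unmeasured. Its relation to compound 3 is this: the two compounds have the same atoms and bonds and differ only in configuration as drawn: 1 of 1 stereo elements differ; a stereocentre at a saturated ring carbon is drawn R in compound 3 and S in compound 4. A stereocentre at a saturated ring carbon is drawn R in compound 3 and S in compound 4.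

Going by the values given here, one measured step bears on this change: a number 0.02 log units higher from compound 1 to compound 2 (within the scatter). It is the same kind of step, a single stereocentre at a saturated ring carbon drawn R and then S, and it rests on (the fact that compounds 1 and 2 differ only in the configuration as drawn). No step beyond the scatter is therefore expected in this assay, and no direction can be assigned. The expected size is a number 0.01 log units higher from compound 3 to compound 4 (within the scatter). For compound 4 the estimate is 2.96, with an expected range from 2.72 to 3.2.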

Compound 4, distribution coefficient: 2.96
Compound 4: the middle estimate sits on the measured number at the digits printed; low and high end bracket the measured number.
By their numbers in this assay, from the lowest: compounds 3, 4, 1 and 2 (each within the scatter of the next).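

Read in this assay, the change of a stereocentre at a saturated ring carbon from R to S now gives a number 0.01 log units higher from compound 3 to compound 4 (within the scatter) in a second pair, and the earlier reading was a number 0.02 log units higher from compound 1 to compound 2 (within the scatter) in the first pair. The absence of a step beyond the scatter on this change, seen before in one pair only, now holds in two. The new reading rests on a single difference: the fact that compounds 3 and 4 differ only in the configuration as drawn.

Going by these compounds, all four compounds carry the same groups on the shared core, and it remains open whether configuration at this carbon would stay without a step in this assay with a group such as an amine or a carboxylic acid on that core. These pairs also speak to this one read-out only and say nothing of configuration in any other measurement.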